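The source may report more compounds than this note shows. Statements on the series, on what has been measured and on what is new or still open speak of the compounds shown alone.

In a functional assay on HeLa cells (Homo sapiens) for inhibition, read by CCK-8 assay, with a stated time of 48 h (on this read-out lower numbers stand for stronger inhibition and higher numbers for weaker inhibition), three compounds have been measured so far. Compound 1 (`COc1ccc(Oc2ccccc2-c2ccsc2S(=O)(=O)N2CCN(C(=S)Nc3ccc([N+](=O)[O-])cc3)CC2)cc1OC`) gives > 50000 nM, which is a limit of the assay and not a number. Compound 3 (`COc1ccc(Oc2ccccc2-c2ccsc2S(=O)(=O)N2CCN(C(=O)Nc3ccc([N+](=O)[O-])cc3)CC2)cc1OC`) gives > 50000 nM, which is also only a limit. Compound 3 therefore stands at the limit of > 50000 nM in this assay, at which 2 of the 3 values shown sit, with no exact place on the scale.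

Within the data shown here, the one measured step is a step that the two limits leave unreadable from compound 1 to compound 3, so it offers no size to carry forward.

Compound 4 (`COc1ccc(Oc2ccccc2-c2ccsc2S(=O)(=O)N2CCN(C(=O)Nc3ccc(F)cc3)CC2)cc1OC`) changes compound 3 in a single place: fluoro in place of nitro on an aromatic carbon. In plain terms, fluoro replaces nitro on an aromatic carbon, turning a 4-nitrophenyl group into a 4-fluorophenyl group. Among the measured compounds shown here, no measured step isolates this swap, so the forecast rests on thin evidence.

For the measured compounds named here, the only hint comes from compound 2 (`O=C(Nc1ccc(F)cc1)N1CCN(S(=O)(=O)c2sccc2-c2ccccc2Oc2ccc(O)c(O)c2)CC1`), the one measured compound that carries a 4-fluorophenyl group and gives a true number, 14800 nM. On that hint alone, a modest move toward stronger inhibition is expected, although a result that stays at the limit would be no surprise.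

The estimated change is an at least 1.5-fold lower number from compound 3 to compound 4 (0.19 log units; that floor lies within the scatter).

For compound 4, the estimate is 32000 nM, with an expected range of 12000 nM to 60000 nM.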

Compound 4, half-maximal inhibitory concentration: > 20000 nM
Compound 4: a limit, no number; the forecaster's own chance of this, stated with the estimate: 45%; the middle value does not contradict the limit.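

In this assay compound 4 gives > 20000 nM, which is a limit of the assay and not a number, and it stands alone at that limit: the limit of > 20000 nM in this assay, at which 1 of the 4 values shown sits.

The steps to compound 4 from compound 1 and from compound 3 have limits at both ends and cannot be read, so fluoro in place of nitro, on an aromatic carbon para to a large group, still has no size. Among these compounds, the one step that can be read, an at least 1.3-fold higher number from compound 2 to compound 4 (0.13 log units; that floor lies within the scatter), is 3,4-dimethoxyphenyl in place of 3,4-dihydroxyphenyl with the 4-fluorophenyl group kept, and it gives no firm sign that this change weakens inhibition.

As far as these compounds go, it remains open whether any compound carrying the 3,4-dimethoxyphenyl group gives a true number in this assay, and so how much the group on the far phenyl ring matters. An amine or a carboxylic acid in the place of nitro and fluoro would be a further test of that position.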